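Sulfonyl substituent change in the shared core series

The source may hold more compounds than are shown below. What is called first, only, known or untested is meant among the compounds shown, and "the series" means these compounds.

Of the compounds shown here, two of the shared core have been measured. Compound 1 `Nc1cccc(-c2ccc3nccc(-c4ccncc4)c3n2)c1` carries an amino group on its aromatic ring; in an ADME assay on microsomes from liver (Rattus norvegicus) for metabolic stability, read by LC-MS, using NADPH, with a stated time of 30 min, tested at 0.1 uM (on this read-out higher numbers stand for a more stable compound and lower numbers for a less stable compound), compound 1 gives 61%. Compound 2 `O=S(=O)(CCO)c1cccc(-c2ccc3nccc(-c4ccncc4)c3n2)c1` carries a (2-hydroxyethyl)sulfonyl group in that place, and in this assay compound 2 gives 59%. For the measured compounds named here, the single step so far, a number 2 percentage points lower from compound 1 to compound 2 (within the scatter), shows no real difference between the two. Compound 2 thus stands at the lowest of the two numbers, but its nearest neighbour, compound 1, lies within the scatter of it, so no order can be read from this.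

Compound 3 `O=S(=O)(c1cccc(-c2ccc3nccc(-c4ccncc4)c3n2)c1)N1CC[C@H](O)C1` has not yet been measured. It differs from compound 2 at the sulfonyl sulfur: 3-hydroxypyrrolidin-1-yl in place of 2-hydroxyethyl on a sulfonyl sulfur. The entering group brings one five-membered non-aromatic ring with one hetero atom and one defined stereocentre, while donor and acceptor counts stay unchanged.

Going by the values given here, no measured step touches this change; the only step available, a number 2 percentage points lower from compound 1 to compound 2 (within the scatter), concerns the other side of the sulfonyl and was within the scatter. With compound 2 at 59% as the reference, the expected step for compound 3 is a number 2 percentage points lower from compound 2 to compound 3 (within the scatter), that is none beyond the scatter. Compound 3 is therefore estimated at 57% in this assay, in the range 40% to 74%.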

Compound 3, percent of the compound remaining: 10%
For compound 3 the middle estimate is 47 percentage points above the measured one; the measured number lies below the stated range.
By their numbers in this assay, from the lowest: compound 3; then compounds 2 and 1 (each within the scatter of the next).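

For the compounds shown here, on the sulfonyl sulfur, the change from 2-hydroxyethyl to 3-hydroxypyrrolidin-1-yl gives the first step beyond the scatter: in this assay there is a number 49 percentage points lower from compound 2 to compound 3 (beyond the scatter) for this single change. Against the amino group on the aromatic carbon, the (3-hydroxypyrrolidin-1-yl)sulfonyl group gives a number 51 percentage points lower from compound 1 to compound 3 (beyond the scatter) in the same read-out, so among these three compounds a sulfonyl group at this place does not go with a low number on its own, since compound 2 stays within the scatter of compound 1, and the outcome turns on what the sulfur carries. Nothing available bears on why this change has so large an effect.

The entering group differs from 2-hydroxyethyl in several features at once, namely the ring, the nitrogen bound to the sulfur and the defined stereocentre, and the compounds shown do not separate them. Open questions are how a dimethylamino or an unsubstituted pyrrolidin-1-yl group on the sulfur would read, how the opposite stereoisomer of the 3-hydroxypyrrolidin-1-yl group would read, and whether a longer chain such as 3-hydroxypropyl would stay level with 2-hydroxyethyl.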